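Chloro in Place of Nitro on a Growth Inhibitor

The source may report more compounds than this note shows. Statements on the series, on what has been measured and on what is new or still open speak of the compounds shown alone.

Of the compounds shown here, two have been tested so far in a functional assay on U-251 cells (Homo sapiens) for inhibition, read by MTT assay, with a stated time of 2 days; on this read-out higher numbers stand for weaker inhibition of growth and lower numbers for stronger inhibition of growth. There, compound 1 `Nc1ccccc1NC(=O)CCCNCC(=O)Nc1ccc(Cl)cc1` gives 11400 nM, and compound 2 `Nc1ccccc1NC(=O)c1ccc(NCC(=O)Nc2ccc([N+](=O)[O-])cc2)cc1` gives 8200 nM. These two numbers lie within the usual scatter of repeated measurements, so compound 2 stands level with compound 1, and neither can be called the better one.

The next molecule, compound 3 `Nc1ccccc1NC(=O)c1ccc(NCC(=O)Nc2ccc(Cl)cc2)cc1`, keeps the core of compound 2 and changes one group. It has chloro in place of nitro on an aromatic carbon, para to a large group, so 4-nitrophenyl becomes 4-chlorophenyl (chloro in place of nitro on an aromatic carbon).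

Among the measured compounds shown here, no two tested compounds differ in one place only, so no measured step shows what this swap does. For the measured compounds named here, the only hint is that compound 1, which already carries 4-chlorophenyl, gives 11400 nM, a number close to that of compound 2. No change beyond the scatter is therefore expected in this assay, and the estimated step is a 1.2-fold lower number from compound 2 to compound 3 (0.07 log units; within the scatter). For compound 3 the expected value is 7000 nM, with an estimated range from 3000 nM to 16000 nM.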

Compound 3, concentration for 50% growth inhibition: 9400 nM
Compound 3: middle estimate off by 1.3-fold (0.13 log units), on the low side; low and high end bracket the measured number.
By their numbers in this assay, from the lowest: compounds 2, 3 and 1 (each within the scatter of the next).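

In this assay, the change of nitro to chloro on the aromatic carbon, para to a large group, now has a measured size, and the swap gives a 1.1-fold higher number from compound 2 to compound 3 (0.06 log units; within the scatter). So, on the core shared by these two compounds, the 4-nitrophenyl and 4-chlorophenyl versions cannot be told apart, even though the group that leaves has 3 heavy atoms and 2 hydrogen-bond acceptors, while the one that enters has 1 heavy atom and no hydrogen-bond acceptors. No measurement at hand offers an explanation for why the two groups read alike.

As far as these compounds go, it remains open whether this position can shift the number at all, since a group of a different kind here, such as an amine or a carboxylic acid, could behave differently from both nitro and chloro. From the compounds shown here alone, it is also open whether the same swap would read the same way with the chain of compound 1 in place of the benzamide-bearing part of compound 3, which a 4-nitrophenyl partner of compound 1 could show.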